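Chain lengthening repeated on a second core

This account rests on a few compounds, and the source may have more. Where it says the series, first, only, none or still open, it means among the compounds named here.

The series is read in a functional assay on MCF7 cells (Homo sapiens) for inhibition, read by radiometric assay and XTT assay; a lower number here means a stronger inhibitor, a higher number a weaker inhibitor. Compound 1 `CCCCCC[C@@]1(C)SC(O)=CC1=O` returns only a limit in this assay, > 80 ug/mL, and so gives no number; it stands at the limit of > 80 ug/mL in this assay, at which 1 of the 3 values shown sits. Compound 2 `CCCCCCCC[C@@]1(C)SC(O)=CC1=O` gives 17.6 ug/mL in this assay. The change between the two is ethyl in place of hydrogen on a saturated chain carbon, six bonds along the chain from a saturated ring carbon, and it brings an at least 4.5-fold lower number from compound 1 to compound 2 (0.65 log units; beyond the scatter); since the starting value is a limit, only the floor of that step is known, not its full size.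

Compound 3 `CCCCCC[C@@]1(C)SC(=O)C=C1OCC(=O)OCC` carries a different core, and how it differs from compound 1 is not broken down here. In this assay compound 3 gives 39.6 ug/mL, the higher of the two numbers in hand, and its gap to compound 2 lies beyond the usual scatter.

Compound 4 `CCCCCCCC[C@@]1(C)SC(=O)C=C1OCC(=O)OCC` is not yet measured. For the measured compounds named here, it differs from compound 3 by ethyl in place of hydrogen on a saturated chain carbon, six bonds along the chain from a saturated ring carbon, which is the same change, at the same place, as the one from compound 1 to compound 2. Going by the values given here, the expected step here, a 4.0-fold lower number from compound 3 to compound 4 (0.60 log units; beyond the scatter), is set beside an at least 4.5-fold lower number from compound 1 to compound 2 (0.65 log units; beyond the scatter), with the caution that the earlier step begins at a limit and that only one such pair is in hand. On that basis compound 4 is estimated to give about 10 ug/mL in this assay, expected to fall between 4 ug/mL and 25 ug/mL.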

Compound 4, half-maximal inhibitory concentration: 35.3 ug/mL
Estimate against measurement, compound 4: 3.5-fold (0.55 log units) below, and the stated range ends below it.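

On the core of compound 3, ethyl in place of hydrogen on a saturated chain carbon, six bonds along the chain from a saturated ring carbon, brings a 1.1-fold lower number from compound 3 to compound 4 (0.05 log units; within the scatter) in this assay, so no change beyond the scatter is seen there. The chain lengthening therefore does not carry over from the core of compound 1 to the core of compound 3 as a step of similar size: the same change on two cores in this assay, an at least 4.5-fold lower number (0.65 log units; beyond the scatter) from compound 1 to compound 2 and a 1.1-fold lower number (0.05 log units; within the scatter) from compound 3 to compound 4, at least 4.0-fold (0.60 log units) apart, beyond the scatter of two such steps

Compound 1 gives only a limit, so the earlier step has a known floor but no known full size, and with a single pair on each core the data show neither why the two steps differ nor whether the difference would hold for other chains: the limit of > 80 ug/mL in this assay, at which 1 of the 4 values shown sits.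

As far as these compounds go, it remains open whether a longer chain, such as decyl, would bring a step beyond the scatter on the core of compound 3 or would extend the step seen on the core of compound 1. From the compounds shown here alone, it is also open whether the difference follows the ethyl ester side group of compound 3 and compound 4, which a carboxylic acid in its place on the same core could help to test.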